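Chain-end swap on the amide series: piperidinyl to chlorophenoxy

The compounds below may be only part of what the source reports. "The series", "measured", "known", "first", "only" and "open" are said of these compounds alone.

The series is followed in an assay for inhibition of acyl-CoA:cholesterol acyltransferase (Oryctolagus cuniculus), using microsomes; on this read-out lower numbers stand for stronger inhibition and higher numbers for weaker inhibition. Compound 1 `CCCCCCCCCCCCCCCC(=O)Nc1cccc2c1OC(C)(C)C2`, carrying an unbranched saturated chain on the amide, gives 890 nM. Compound 2 `Cc1cc(C)c(NC(=O)C(C)(C)CCCCCCN2CCCCC2)c2c1CC(C)(C)O2`, whose chain ends in a piperidin-1-yl group, is reported only as a limit of this assay, > 500 nM, and not as a number; this is the limit of > 500 nM in this assay, at which 1 of the 2 values shown sits. On the numbers shown, compound 2 therefore sits at the weak end, and nothing more exact can be said of where it stands.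

Compound 3 `Cc1cc(C)c(NC(=O)C(C)(C)CCCCCCOc2ccc(Cl)cc2)c2c1CC(C)(C)O2` is not yet measured. It differs from compound 2 by 4-chlorophenoxy in place of piperidin-1-yl on a saturated chain carbon, seven bonds along the chain from a carbonyl carbon. Among the compounds with values here, no measured step in this assay covers a change of this kind, so the expected size of the step has no direct precedent. The expectation is a modest gain in this assay, of a size that could still fall within the scatter, so that compound 3 with its 4-chlorophenoxy end is expected to come somewhat closer to compound 1 at 890 nM than compound 2 does. The expected step is a step that the limit leaves unreadable from compound 2 to compound 3. For compound 3 the estimate in this assay is 600 nM, with a range from 150 nM to 2500 nM.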

Compound 3, half-maximal inhibitory concentration: 76 nM
Compound 3: the middle estimate sits 7.9-fold (0.90 log units) above what was measured; the measured number lies below the stated range.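

In this assay, the group at the chain end, seven bonds along the chain from a carbonyl carbon, proves able to move the read-out: 4-chlorophenoxy in place of piperidin-1-yl gives an at least 6.5-fold lower number from compound 2 to compound 3 (0.81 log units; beyond the scatter). Within the data shown here, compound 3 also provides the first exact number for this shared core and chain, so the position can now be followed by numbers from compound 3 onward. Going by these compounds, the true size of the step remains open-ended, since compound 2 is recorded as a limit and not as a number: the limit of > 500 nM in this assay, at which 1 of the 3 values shown sits.

The single change swaps a non-aromatic nitrogen ring for a chlorinated aromatic ring joined through an ether oxygen, so the compounds shown do not separate the contributions of the chlorine, the oxygen and the aromatic ring; an unsubstituted phenoxy, a 4-fluorophenoxy or a 4-chlorophenyl end would begin to pull these apart. On these data alone, how far the result holds with a shorter or longer chain between the amide and the 4-chlorophenoxy group, or with a morpholin-4-yl end in place of piperidin-1-yl, also remains open.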